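Swapping Cyclopropyl for Methyl on a Chlorinated Amide Series

The compounds below may be only part of what the source reports. "The series", "measured", "known", "first", "only" and "open" are said of these compounds alone.

Compound 1 `O=C(/C=C1\CCc2cc(Cl)ccc21)NC1CC1`: 17%
Compound 2 `CNC(=O)/C=C1\CCc2ccc(Cl)cc21`: 16%
Compound 3 `O=C(/C=C1\CCc2ccc(Cl)cc21)NC1CC1`: 50%

These three compounds were tested in a functional assay on the whole organism with Mus musculus as the target, at a dose of 100 mg/kg by the intraperitoneal route; a lower number here means less inhibition, a higher number more inhibition at the dose given (going by the name of the read-out). One structural change has been measured directly, from compound 3 to compound 2: methyl in place of cyclopropyl on an amide-type nitrogen. That change made a number 34 percentage points lower from compound 3 to compound 2 (beyond the scatter). The same change turns compound 1 into the unmeasured compound 4 `CNC(=O)/C=C1\CCc2cc(Cl)ccc21`: methyl in place of cyclopropyl on an amide-type nitrogen. Compound 1 and compound 3 share their atoms but join them differently; the difference between the two cores is not broken down here. Compound 1 and compound 2 give numbers within the scatter of each other. Because compound 1 starts from 17%, a drop as large as the earlier step has no room on the scale, so a smaller step down is expected for compound 4, a number 8 percentage points lower from compound 1 to compound 4 (within the scatter). Compound 4 is therefore estimated at 9%, expected to lie between 0% and 22%.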

Compound 4, a percentage reported as inhibition, in the whole organism at one dose (the size of the read-out at that dose, not a potency): 50%
For compound 4 the middle estimate is 41 percentage points below the measured one, outside the stated range (above it).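

In this assay, putting methyl in place of cyclopropyl on an amide-type nitrogen gave a number 33 percentage points higher from compound 1 to compound 4 (beyond the scatter), so the change did not carry over from one core to the other, even in direction: the same change on two cores in this assay, a number 34 percentage points lower (beyond the scatter) from compound 3 to compound 2 and a number 33 percentage points higher (beyond the scatter) from compound 1 to compound 4, 67 percentage points apart, beyond the scatter of two such steps

The outcome of this swap therefore depends on the core it is made on, and a step read on one of these cores is a poor guide to the other. These two pairs do not show why the cores respond in opposite ways, and they say nothing about any further core.

The compounds shown leave open how an ethyl group, a longer chain or a cyclobutyl ring on the same nitrogen would behave on either core.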